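A few compounds are considered here, and "the series" means these few. Any claim that something is new, unique, unknown or untested is made for them only; others in the source may bear on it.

Measured compounds on the shared core:

- compound 1 `O=C(O)CNC(=O)COc1ccc([C@H]2CC[C@]3(CC2)OOC2(O3)C3CC4CC(C3)CC2C4)cc1` — < 7 mL.min-1.g-1 in an ADME assay on microsomes from liver (Homo sapiens) for metabolic stability, using NADPH, with a stated time of 60 min, in the presence of a further agent that is not named here; on this read-out higher numbers stand for fast clearance and lower numbers for slow clearance; this is a limit of the assay, not a number.
- compound 2 `O=C(O)COc1ccc([C@H]2CC[C@]3(CC2)OOC2(O3)C3CC4CC(C3)CC2C4)cc1Cl` — < 7 mL.min-1.g-1; again a limit of the assay.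
- compound 3 `O=C(O)COc1ccc([C@H]2CC[C@]3(CC2)OOC2(O3)C3CC4CC2CC(C3)C4(F)F)cc1` — 23 mL.min-1.g-1.

Compound 1 therefore stands at the limit of < 7 mL.min-1.g-1 in this assay, at which 2 of the 3 values shown sit; only compound 3 reports a number, and nothing more can be said of the gap between compound 1 and compound 3 than that one sits at the limit and the other does not. Going by the values given here, no single-change pair among the measured compounds is available.

Compound 4 `CS(=O)(=O)NC(=O)COc1ccc([C@H]2CC[C@]3(CC2)OOC2(O3)C3CC4CC(C3)CC2C4)cc1` differs from compound 1 by methylsulfonyl in place of carboxymethyl on an amide-type nitrogen. The step is a swap of the acid-bearing end of the side chain for a sulfonyl group at the same amide-type nitrogen, and the rest of the molecule is unchanged. With compound 1 at the limit, the step from compound 1 to compound 4 in this assay is expected to be small, within the usual scatter or only slightly upward: an at least 1.1-fold higher number from compound 1 to compound 4 (0.05 log units; that floor lies within the scatter). Compound 4 is thus estimated at 8 mL.min-1.g-1, with a range from 4 mL.min-1.g-1 to 20 mL.min-1.g-1, and a fair chance that the assay again reports only a limit.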

Compound 4, intrinsic clearance in microsomes: < 7 mL.min-1.g-1
Compound 4 gave a limit, no number; the forecaster's own chance of this, stated with the estimate: 45%; middle value at least 1.1-fold (0.05 log units) from the limit.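

In this assay, going by these compounds alone, compound 1 and compound 4 both sit at a limit of the assay, so no step between them can be read: the limit of < 7 mL.min-1.g-1 in this assay, at which 3 of the 4 values shown sit.

Still open, going by these compounds, is whether methylsulfonyl in place of carboxymethyl on an amide-type nitrogen changes clearance at all.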